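Trimming an Ethyl to a Methyl: Plasma Stability Outlook

The compounds below may be only part of what the source reports. "The series", "measured", "known", "first", "only" and "open" are said of these compounds alone.

Compound 1 `CCN1CCC(c2ccc3c(c2)oc(=O)n3C(=O)NCCCCc2ccccc2)CC1` carries a 1-ethylpiperidin-4-yl group on its shared core. In an ADME assay on a cell-free system (plasma, Mus musculus) for metabolic stability, read by LC-MS, tested at 2 uM (a higher number here means that the compound lasts longer, a lower number that the compound disappears faster), compound 1 gives 0.833 h. Compound 2 `O=C(NCCCCc1ccccc1)n1c2c(oc1=O)CCNC2` is the other measured member of the set. In this assay compound 2 reaches only a limit of the assay, > 2 h. Among the two values shown, compound 1 therefore provides the only actual number, while the other entry is a limit, (the limit of > 2 h in this assay, at which 1 of the 2 values shown sits). Going by the values given here, no pair of measured compounds differs in just one place, so no measured step connects compound 1 and compound 2, and nothing can be said of what separates them beyond their two values.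

Compound 3 `CN1CCC(c2ccc3c(c2)oc(=O)n3C(=O)NCCCCc2ccccc2)CC1` differs from compound 1 by hydrogen in place of methyl on a saturated chain carbon bound to an amine nitrogen in a ring. In other words, the 1-ethylpiperidin-4-yl group of compound 1 becomes 1-methylpiperidin-4-yl in compound 3. Among the compounds with values here, no measured step in the set shows how the half-life in this assay responds to such a change. The step from compound 1 to compound 3 is therefore expected to be small, none beyond the scatter, a 1.2-fold higher number from compound 1 to compound 3 (0.08 log units; within the scatter). Compound 3 is expected to give 1 h in this assay, within a range from 0.5 h to 2 h.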

Compound 3, half-life: 0.833 h
For compound 3 the middle estimate is 1.2-fold (0.08 log units) above the measured one; the range from low to high includes it.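

Replacing the 1-ethylpiperidin-4-yl group with 1-methylpiperidin-4-yl gives the set its first measured step, and in this assay it reads no change at the digits printed from compound 1 to compound 3 (within the scatter) for this change. Going by these compounds alone, at this place, on a saturated chain carbon bound to an amine nitrogen in a ring, ethyl and methyl therefore give the same half-life at the digits printed, something the earlier compounds could not show with no step between them. Nothing in the data shown bears on why the half-life holds across this change.

Going by these compounds, what remains open is whether this holds beyond these two small groups, for instance with a longer chain such as propyl, a branched isopropyl, a benzyl, or the free amine with no alkyl group at all in this place. A single step at one position also leaves the response elsewhere on the shared core unknown, and the entry for compound 2 is a limit, on a compound that no single change connects to compound 1 or compound 3.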